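Fluoro for Methyl on the Pyridinyl Ether: Expected Permeability

The source may hold more compounds than are shown below. What is called first, only, known or untested is meant among the compounds shown, and "the series" means these compounds.

Compound 1 `Cc1ccnc(Oc2ccc3nc(COc4cccc(C(=O)O)c4)n(C)c3c2)c1` and compound 2 `Cc1cccnc1Oc1ccc2nc(COc3cccc(C(=O)O)c3)n(C)c2c1` share a core and differ only in the group on an oxygen on an aromatic ring. In an ADME assay for permeability, using PAMPA, with a stated time of 4 h (on this read-out higher numbers stand for higher permeability and lower numbers for lower permeability), compound 1 gives 3.5 10^-6 cm/s, and compound 2 gives 6 10^-6 cm/s; the two numbers lie within the scatter of one another, as a 1.7-fold higher number from compound 1 to compound 2 (0.23 log units; within the scatter) shows. Compound 3 `Cn1c(COc2cccc(C(=O)O)c2)nc2ccc(Oc3ncccc3F)cc21` carries fluoro in place of methyl on an aromatic carbon. Going by the values given here, no measured step swaps methyl for fluoro, so the one measured step offers no direct guide. The step expected for compound 3 is no change at the digits printed from compound 2 to compound 3 (within the scatter), not beyond the scatter. The estimate for compound 3 is 6 10^-6 cm/s, between 3 10^-6 cm/s and 12 10^-6 cm/s.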

Compound 3, apparent permeability: 3.9 10^-6 cm/s
Compound 3: middle estimate off by 1.5-fold (0.19 log units), on the high side; measured number inside the range.
By their numbers in this assay, from the lowest: compounds 1, 3 and 2 (each within the scatter of the next).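

In this assay, fluoro in place of methyl on this aromatic carbon, two atoms from the ring nitrogen, gives a 1.5-fold lower number from compound 2 to compound 3 (0.19 log units; within the scatter), so this swap of one heavy atom for another stays inside the scatter. The 3-fluoropyridin-2-yl group also stays within the scatter of the 4-methylpyridin-2-yl group, with a 1.1-fold higher number from compound 1 to compound 3 (0.05 log units; within the scatter) on the same read-out. Going by these compounds, whether an amine or a methoxy group on that carbon would take the number beyond the scatter remains open. Nothing available here bears on what lies behind these numbers.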